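What One Aromatic Swap May Do to Stability

The compounds below may be only part of what the source reports. "The series", "measured", "known", "first", "only" and "open" are said of these compounds alone.

In an ADME assay on microsomes from liver (Homo sapiens) for metabolic stability, with a stated time of 60 min, tested at 10 uM (a lower number here means that less of the compound is left, a higher number that more of the compound is left), compound 1 (`CCCS(=O)(=O)N1CCN(C2(CNC(=O)c3ccccc3OC(F)(F)F)CCCCC2)CC1`) gives 2%, and compound 2 (`CCCS(=O)(=O)N1CCN(C2(CNC(=O)c3c(Cl)cccc3Cl)CCCCC2)CC1`) gives 3%. These two numbers lie within the scatter of each other, so compound 2 stands level with compound 1, with very little left at the end of the test.

Compound 3 (`CCCS(=O)(=O)N1CCN(C2(CNC(=O)c3c(OC)cc(F)cc3SC)CCCCC2)CC1`) keeps the shared core but carries 4-fluoro-2-methoxy-6-(methylsulfanyl)phenyl in place of 2,6-dichlorophenyl on a carbonyl carbon.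

Among the measured compounds shown here, only one measured step bears on this, a swap at the same place: a number 1 percentage points higher from compound 1 to compound 2 (within the scatter). One small step is thin evidence, but it gives no reason to expect a change beyond the scatter in this assay, in either direction. The expected step is a number 2 percentage points higher from compound 2 to compound 3 (within the scatter). For compound 3 the estimated value is 5%, with a range from 1% to 15%.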

Compound 3, percent of the compound remaining: 1%
The estimate for compound 3 lay 4 percentage points above the measured number; low and high end bracket the measured number.
By their numbers in this assay, from the lowest: compounds 3, 1 and 2 (each within the scatter of the next).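

Going from the 2,6-dichlorophenyl group to the 4-fluoro-2-methoxy-6-(methylsulfanyl)phenyl group adds heavy atoms and hydrogen-bond acceptors, yet this assay shows a number 2 percentage points lower from compound 2 to compound 3 (within the scatter). Set against the first group in the series, the new group gives a number 1 percentage points lower from compound 1 to compound 3 (within the scatter), so three differently substituted aromatic groups on this carbonyl carbon now stand level, each with very little compound left at the end of the test. No supporting measurement is available to explain these low numbers.

As far as these compounds go, it remains open whether an amine or a carboxylic acid on the aromatic ring would leave more of the compound in this assay. From the compounds shown here alone, it is equally open whether a change elsewhere in the shared core, such as a longer chain on the sulfonyl group, would matter more than any swap at this place.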